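From propoxy to 2-phenoxyethoxy on compound 2

A few compounds are considered here, and "the series" means these few. Any claim that something is new, unique, unknown or untested is made for them only; others in the source may bear on it.

Of the compounds shown here, two have been measured so far in an ADME assay on RAW264.7 cells (Mus musculus) for cytotoxicity, read by MTT assay, with a stated time of 24 h, in the absence of a further agent; on this read-out higher numbers stand for weaker inhibition and lower numbers for stronger inhibition. Compound 1 `O=C1OC(Cc2nc(Cc3ccccc3)no2)c2ccccc21` gives > 40000 nM, which is a limit of the assay and not a number. Compound 2 `CCCOc1ccc(C(O)C2OC(=O)c3c(OC)cc(OC)cc32)cc1` gives > 40000 nM, which is likewise only a limit. Compound 3 `COc1cc(OC)c2c(c1)C(C(O)c1ccc(OCCOc3ccccc3)cc1)OC2=O` has not yet been measured in this assay. It differs from compound 2 by one change, phenoxy in place of methyl on a saturated chain carbon, two bonds along the chain from an oxygen on an aromatic ring. With compound 2 at > 40000 nM, a limit, no shift in either direction beyond the scatter is expected. The expected step that the limit leaves unreadable from compound 2 to compound 3 is therefore small. For compound 3 the estimated value is 45000 nM, with an expected range from 20000 nM to 80000 nM. The assay may well report only a limit again.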

Compound 3, half-maximal inhibitory concentration: > 40000 nM
Compound 3 ended at the assay's limit; the forecaster's own chance of this, stated with the estimate: 80%; the middle value is on the limit's open side.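

Compound 2 and compound 3 both give only a limit in this assay, so the step between them cannot be read. The compounds shown leave open what actual value any of them would reach, and whether the change to phenoxy has any effect, as all stand at one mark: the limit of > 40000 nM in this assay, at which 3 of the 3 values shown sit.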